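From oxan-3-yl to 4-hydroxypiperidin-1-yl on a sulfonyl sulfur

A few compounds are considered here, and "the series" means these few. Any claim that something is new, unique, unknown or untested is made for them only; others in the source may bear on it.

Measured so far in a physicochemical assay for solubility, in phosphate buffer, with a stated time of 24 h, at pH 7.4, tested at 100 uM; a lower number here means a less soluble compound, a higher number a more soluble compound:
compound 1 `O=C(NCc1ccc(S(=O)(=O)c2cncc(C(F)(F)F)c2)cc1)N1Cc2ccncc2C1`: 83000 nM
compound 2 `O=C(NCc1ccc(S(=O)(=O)C2CCOCC2)cc1)N1Cc2ccncc2C1`: 206000 nM
compound 3 `O=C(NCc1ccc(S(=O)(=O)C2CCCOC2)cc1)N1Cc2ccncc2C1`: 208000 nM

The number for compound 3 cannot be told apart from that for compound 2, and both sit beyond the scatter above compound 1. The next molecule, compound 4 `O=C(NCc1ccc(S(=O)(=O)N2CCC(O)CC2)cc1)N1Cc2ccncc2C1`, has not been measured. It differs from compound 3 by 4-hydroxypiperidin-1-yl in place of oxan-3-yl on a sulfonyl sulfur.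

Going by the values given here, no measured step makes this exact swap. The closest one exchanges one six-membered non-aromatic ring for another, and the step of a 1.0-fold higher number from compound 2 to compound 3 (0.00 log units; within the scatter) stays within the scatter. The modest steps of a 2.5-fold higher number from compound 1 to compound 2 (0.39 log units; beyond the scatter) and a 2.5-fold higher number from compound 1 to compound 3 (0.40 log units; beyond the scatter) instead replace 5-(trifluoromethyl)pyridin-3-yl, so they bear on this change less directly. Three compounds are thin evidence, but no step beyond the scatter is expected in this assay. The expected step is a 1.1-fold lower number from compound 3 to compound 4 (0.04 log units; within the scatter). The estimate for compound 4 is 190000 nM, with an expected range of 90000 nM to 300000 nM.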

Compound 4, solubility: 174000 nM
Compound 4: the middle estimate sits 1.1-fold (0.04 log units) above what was measured, within the range that was stated.
By their numbers in this assay, from the lowest: compound 1; then compounds 4, 2 and 3 (each within the scatter of the next).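

In this assay, placing 4-hydroxypiperidin-1-yl on a sulfonyl sulfur gives a 1.2-fold lower number from compound 3 to compound 4 (0.08 log units; within the scatter) and a 1.2-fold lower number from compound 2 to compound 4 (0.07 log units; within the scatter), so this position accepts a ring that brings in a nitrogen and a hydrogen-bond donor with no step beyond the scatter. Against the aromatic group of compound 1, the result is a 2.1-fold higher number from compound 1 to compound 4 (0.32 log units; beyond the scatter), so all three six-membered non-aromatic rings now stand modestly clear of 5-(trifluoromethyl)pyridin-3-yl. No measurement shown here explains these steps.

Still open, from the compounds shown here alone, is how a carboxylic acid or a primary amine on the ring, or a short open chain in place of the ring, would behave on the sulfonyl sulfur. A plain phenyl ring there would help show whether the gap to compound 1 follows the aromatic ring or the trifluoromethyl group.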